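Shifting a benzyl substituent from bromo to trifluoromethyl

The compounds below may be only part of what the source reports. "The series", "measured", "known", "first", "only" and "open" are said of these compounds alone.

Compound 1 `OC[C@H]1O[C@@H](n2cnc3c(NCc4ccccc4Br)ncnc32)[C@H](O)[C@@H]1O` is the only one of the three measured compounds to give a number in a functional assay on K562 cells (Homo sapiens) for antiproliferative activity, with a stated time of 72 h; a higher number here means a weaker inhibitor, a lower number a stronger inhibitor: compound 1 gives 10000 nM. Compound 2 `OC[C@H]1O[C@@H](n2cnc3c(NCc4cc(O)cc(O)c4)ncnc32)[C@H](O)[C@@H]1O` reaches only the limit of the assay, > 166000 nM. Compound 3 `OC[C@H]1O[C@@H](n2cnc3c(NCc4ccccc4OC(F)F)ncnc32)[C@H](O)[C@@H]1O` likewise stops at a limit, > 166000 nM. The step from compound 2 to compound 3 is a step that the two limits leave unreadable from compound 2 to compound 3. Compound 4 `OC[C@H]1O[C@@H](n2cnc3c(NCc4ccc(C(F)(F)F)cc4)ncnc32)[C@H](O)[C@@H]1O` differs from compound 1 in one place: 4-(trifluoromethyl)phenyl in place of 2-bromophenyl on a saturated chain carbon bound to a nitrogen on an aromatic ring. Both measured changes at this position were large, an at least 16-fold higher number from compound 1 to compound 2 (1.22 log units; beyond the scatter) and an at least 16-fold higher number from compound 1 to compound 3 (1.22 log units; beyond the scatter), each ending at the limit of > 166000 nM in this assay, at which 2 of the 3 values shown sit, so the step to compound 4 is expected to be a 6.0-fold higher number from compound 1 to compound 4 (0.78 log units; beyond the scatter). Compound 4 is therefore estimated at 60000 nM, within a range from 10000 nM to 300000 nM, with a fair chance that only a limit is reported.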

Compound 4, half-maximal inhibitory concentration: > 166000 nM
Compound 4 gave a limit, no number (the forecaster's own chance of this, stated with the estimate: 50%); at least 2.7-fold (0.44 log units) between middle value and limit.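

With 4-(trifluoromethyl)phenyl on the saturated chain carbon, this assay shows an at least 16-fold higher number from compound 1 to compound 4 (1.22 log units; beyond the scatter), so a third replacement of 2-bromophenyl, this one with no hydrogen-bond donors, also loses the measured number. Compound 4 stops at a limit, leaving compound 1 the only compound shown with a number: the limit of > 166000 nM in this assay, at which 3 of the 4 values shown sit. The steps among compound 2, compound 3 and compound 4 cannot be read. On these data alone, what stays open is whether any group other than 2-bromophenyl gives a number here, such as 2-chlorophenyl, an aminophenyl or a longer chain carrying the phenyl ring.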